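This account rests on a few compounds, and the source may have more. Where it says the series, first, only, none or still open, it means among the compounds named here.

In an assay on cells for inhibition of Voltage-dependent T-type calcium channel subunit alpha-1H (Homo sapiens), read by FLIPR and calcium flux, with stated times of 600 s and 300 s (on this read-out lower numbers stand for stronger inhibition and higher numbers for weaker inhibition), compound 3 `N=C(N)NCCCOc1ccc(CNc2nc3ccc(Oc4ccc(F)cc4)cc3s2)cc1` gives 288000 nM, a number that sits alongside compound 1 `N=C(N)NCCCOc1ccc(CNc2nc3ccc(Oc4cccc(C(F)(F)F)c4)cc3s2)cc1` with 270000 nM and compound 2 `CN(Cc1ccc(OCCCNC(=N)N)cc1)c1nc2ccc(Oc3ccc(O)cc3)cc2s1` with 332000 nM; all three lie within the scatter of one another, so none can be called stronger or weaker. Compound 4 `N=C(N)NCCCOc1ccc(CNc2nc3ccc(Oc4ccc(O)cc4)cc3s2)cc1` differs from compound 3 by one change: hydroxy in place of fluoro on an aromatic carbon. Among the measured compounds shown here, only one measured step touches this part of the structure, the swap of the aromatic group on the same oxygen, which gave a 1.1-fold higher number from compound 1 to compound 3 (0.03 log units; within the scatter), and compound 2, which also carries a 4-hydroxyphenoxy group, shows a number in the same narrow band. Nothing here points to a move beyond the scatter, so compound 4 is expected to give 300000 nM (range 150000 nM to 600000 nM), an estimated step of a 1.0-fold higher number from compound 3 to compound 4 (0.02 log units; within the scatter).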

Compound 4, half-maximal inhibitory concentration: 319000 nM
Compound 4: middle estimate off by 1.1-fold (0.03 log units), on the low side; measured number inside the range.
By their numbers in this assay, from the lowest: compounds 1, 3, 4 and 2 (each within the scatter of the next).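

In this assay, hydroxy in place of fluoro on this aromatic carbon gives a 1.1-fold higher number from compound 3 to compound 4 (0.04 log units; within the scatter), so this single swap, which adds a hydrogen-bond donor, shifts the number by no more than the scatter. Hydrogen in place of methyl on the nitrogen gives a 1.0-fold lower number from compound 2 to compound 4 (0.02 log units; within the scatter), the first reading of that change. 4-hydroxyphenyl in place of 3-(trifluoromethyl)phenyl gives a 1.2-fold higher number from compound 1 to compound 4 (0.07 log units; within the scatter), again within the scatter. Nothing available explains why these numbers stay so close. Going by these compounds, whether an amine or a carboxylic acid on this aromatic carbon would move the number beyond the scatter remains open.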